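The compounds below may be only part of what the source reports. "The series", "measured", "known", "first", "only" and "open" are said of these compounds alone.

Measured compounds:
Compound 1 `CCN(CC)c1cc2[nH]c(C3CCCCC3)nc2cc1NC(=O)c1ccc(F)cc1F`: in an ADME assay on Vero cells (Chlorocebus sabaeus) for cytotoxicity, read by resazurin assay, with a stated time of 3 days (a lower number here means a stronger inhibitor, a higher number a weaker inhibitor), compound 1 gives > 100 ug/mL, which is a limit of the assay rather than a number.
Compound 2 `CCCN(CCC)c1cc2[nH]c(C3CCCCC3)nc2cc1NC(=O)c1ccccc1`: in this assay compound 2 gives > 100 ug/mL, again a limit.
Compound 3 `CN(C)c1cc2[nH]c(C3CCCCC3)nc2cc1NC(=O)c1ccc(F)cc1F`: in this assay compound 3 gives > 100 ug/mL, also a limit.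

Compound 1 thus stands only at a limit, as do the two other values shown; all three sit at the limit of > 100 ug/mL in this assay, at which 3 of the 3 values shown sit. Among the compounds with values here, the single step between measured compounds that differ in one place, a step that the two limits leave unreadable from compound 1 to compound 3, runs between two limits and its size cannot be read.

Compound 4 `CCCC(C)OC(=O)Nc1cc2nc(C3CCCCC3)[nH]c2cc1N(CC)CC` differs from compound 1 by 1-methylbutoxy in place of 2,4-difluorophenyl on a carbonyl carbon. Within the data shown here, no measured step touches this position; the step from compound 1 to compound 3 concerns a different part of the shared core and is unreadable in any case. With every value at the limit, nothing indicates a step in this assay beyond the scatter in either direction. Compound 4 is therefore expected to remain near the same limit, the estimated step of a number no higher from compound 1 to compound 4 (the limit leaves the size open) being essentially a continuation. Compound 4 is expected at 100 ug/mL, with a range from 40 ug/mL to 300 ug/mL.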

Compound 4, half-maximal inhibitory concentration: > 100 ug/mL
Compound 4: no number, only a limit; the forecaster's own chance of this, stated with the estimate: 70%; the middle value lies on the limit itself.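

No new step can be read between compound 1 and compound 4, since each stands only at a limit in this assay: the limit of > 100 ug/mL in this assay, at which 4 of the 4 values shown sit. The compounds shown leave open where the true values lie and whether any change on the shared core alters them.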